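Clearance notes: isopropyl to methyl on the shared core

The compounds below may be only part of what the source reports. "The series", "measured", "known", "first", "only" and "open" are said of these compounds alone.

In an in vitro ADME assay on microsomes from liver (Homo sapiens) for metabolic stability, tested at 0.2 uM (on this read-out lower numbers stand for slow clearance and higher numbers for fast clearance), the series has only limits so far. Compound 1 (`CCCCOc1cccc(OCc2[nH]c3ccccc3c(=O)c2C)c1`) gives > 1000 mL/min/kg as its result, and this is a limit rather than a number. Compound 2 (`Cc1c(COc2cccc(OCC3CCOCC3)c2)[nH]c2ccc(C(=O)O)cc2c1=O`) gives < 20 mL/min/kg as its result, again a limit and not a number. Compound 3 (`CC(C)c1c(COc2cccc(OCC3CCOCC3)c2)[nH]c2ccccc2c1=O`) has the entry "not determined" (no result reported) in this read-out, so it has no position on the scale.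

Compound 4 (`Cc1c(COc2cccc(OCC3CCOCC3)c2)[nH]c2ccccc2c1=O`) carries methyl in place of isopropyl on an aromatic carbon and still awaits measurement. For the measured compounds named here, no measured pair differs in one place only, so no step size can be taken from the data. A moderate step towards lower clearance, beyond the usual scatter, is tentatively expected in this assay for this change, although the missing number for compound 3 means it could not be read directly. For compound 4 the estimated clearance is 150 mL/min/kg with an expected range from 40 mL/min/kg to 500 mL/min/kg in this assay.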

Compound 4, clearance: 214 mL/min/kg
Compound 4: the middle estimate sits 1.4-fold (0.15 log units) below what was measured; measured number inside the range.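

For the compounds shown here, compound 4 is the first compound in this assay with a number rather than a limit, so methyl on this aromatic carbon, two atoms from the ring nitrogen, now has a place on the scale. With hydrogen in place of carboxy the series shows an at least 10-fold higher number from compound 2 to compound 4 (1.02 log units; beyond the scatter) and with oxan-4-yl in place of propyl it shows an at least 4.6-fold lower number from compound 1 to compound 4 (0.66 log units; beyond the scatter) and both steps start from a limit of the assay, so each gives only a minimum size. The step between isopropyl and methyl cannot be read, as compound 3 has no result on this scale.

Where ethyl or a longer chain on this aromatic carbon would fall on the scale stays open, as does the effect of an amine on the shared core. Nothing in the data shown gives a reason for either step.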